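Cyano removal on the biphenylmethyl urea series

This account rests on a few compounds, and the source may have more. Where it says the series, first, only, none or still open, it means among the compounds named here.

Measured so far in an in vitro functional assay on HEK293 cells for antagonist activity at melanin-concentrating hormone receptor 1 (Homo sapiens), read by GTPgammaS binding, with a stated time of 45 min; a higher number here means a weaker inhibitor, a lower number a stronger inhibitor:
compound 1 `Cc1ccc(CN2CCC(CCN(Cc3ccc(-c4ccccc4)cc3)C(=O)NC(C)C)CC2)cc1` gives 220 nM
compound 2 `CC(=O)OCC(C)(C)NC(=O)N(CCC1CCN(Cc2ccc(C)cc2)CC1)Cc1ccc(-c2ccccc2)cc1` gives 366 nM
compound 3 `Cc1ccc(CN2CCC(CCN(Cc3ccc(-c4cccc(C#N)c4)cc3)C(=O)NC(C)(C)CO)CC2)cc1` gives 84 nM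

Compound 3 stands lowest of the three numbers in this assay; the gap to compound 1 and the larger gap to compound 2 are both beyond the scatter. Compound 4 `Cc1ccc(CN2CCC(CCN(Cc3ccc(-c4ccccc4)cc3)C(=O)NC(C)(C)CO)CC2)cc1` differs from compound 3 in one place: hydrogen in place of cyano on an aromatic carbon. Among the measured compounds shown here, no measured step touches this position. For the measured compounds named here, the only single-place step, a 1.7-fold higher number from compound 1 to compound 2 (0.22 log units; within the scatter), sits on the urea substituent and stays within the scatter, so it bears only loosely here. Compound 1 carries the phenyl that enters in compound 4 together with a different urea substituent, which points to a number between compound 3 and compound 1. A moderate rise in the number is expected, a 1.8-fold higher number from compound 3 to compound 4 (0.25 log units; within the scatter). Compound 4 is estimated at 150 nM, within 60 nM to 400 nM.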

Compound 4, antagonist equilibrium constant: 122 nM
Compound 4: middle estimate off by 1.2-fold (0.09 log units), on the high side; low and high end bracket the measured number.
By their numbers in this assay, from the lowest: compounds 3, 4, 1 and 2 (each within the scatter of the next, the first and the last beyond it).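

In this assay, the 3-cyanophenyl to phenyl change gives a 1.5-fold higher number from compound 3 to compound 4 (0.16 log units; within the scatter), so at this position on the shared core, the nitrile can leave without a step beyond the scatter. Among the compounds shown here, with phenyl fixed, the urea substituent gives a 1.8-fold lower number from compound 1 to compound 4 (0.26 log units; within the scatter) for the added hydroxymethyl and a 3.0-fold lower number from compound 2 to compound 4 (0.48 log units; beyond the scatter) for removal of the acetyl, the only one of these steps beyond the scatter. Nothing on hand explains these steps.

Open, going by these compounds, is how a methoxy group, an amine or a carboxylic acid on that aromatic carbon would read. Also open, on these data alone, is whether the nitrile step holds with other urea substituents.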